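Cyanophenyl Replaces Hydroxyphenyl: Tolerance on Vero Cells

This account rests on a few compounds, and the source may have more. Where it says the series, first, only, none or still open, it means among the compounds named here.

The measured compounds, with their read-outs in an ADME assay on Vero cells (Chlorocebus sabaeus) for cytotoxicity; a higher number here means that more compound is tolerated, a lower number that less compound is tolerated:
Compound 1 `COc1ccc(-c2nc3c(NC4CCCC4)cccn3c2-c2ccnc(NC3CCCC3)n2)cc1` gives a value that is only a limit, > 10000 nM.
Compound 2 `COc1cccc(-c2nc3c(NC4CCCC4)cccn3c2-c2ccnc(NC3CCCC3)n2)c1` gives a value that is only a limit, > 40000 nM.
Compound 3 `Oc1cccc(-c2nc3c(NC4CCCC4)cccn3c2-c2ccnc(NC3CCCC3)n2)c1` gives a value that is only a limit, > 40000 nM.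

Compound 3 therefore stands on a limit in this assay, and the two other values shown are limits as well, so no number places it against them. The step that the two limits leave unreadable from compound 1 to compound 2, the step that the two limits leave unreadable from compound 1 to compound 3 and the step that the two limits leave unreadable from compound 2 to compound 3 are all unreadable, since each rests on limits: the limit of > 10000 nM in this assay, at which 1 of the 3 values shown sits, and (the limit of > 40000 nM in this assay, at which 2 of the 3 values shown sit).

Compound 4 `N#Cc1ccc(-c2nc3c(NC4CCCC4)cccn3c2-c2ccnc(NC3CCCC3)n2)cc1` differs from compound 3 in one place: 4-cyanophenyl in place of 3-hydroxyphenyl on an aromatic carbon. Among the compounds with values here, none of the measured steps can be read for size, so none gives a direction for this change in this assay. Compound 4 is expected to stay at a limit as well, with an estimated 40000 nM between 10000 nM and 120000 nM, and the estimated step of a number no higher from compound 3 to compound 4 (the limit leaves the size open) is expected to be within the scatter.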

Compound 4, half-maximal cytotoxic concentration: > 40000 nM
Compound 4 gave a limit, no number; the forecaster's own chance of this, stated with the estimate: 80%; the middle value sits exactly at the limit.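

The steps from compound 1, compound 2 and compound 3 to compound 4 in this assay cannot be read for size, since all of them rest on limits: the limit of > 10000 nM in this assay, at which 1 of the 4 values shown sits, and (the limit of > 40000 nM in this assay, at which 3 of the 4 values shown sit).

The compounds shown leave open whether any of these changes moves the read-out in this assay at all.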